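The compounds below may be only part of what the source reports. "The series", "measured", "known", "first", "only" and "open" are said of these compounds alone.

Compound 1 `NC(=O)C1CCN(Cc2ccc([C@H]3CC[C@]4(CC3)OOC3(O4)C4CC5CC(C4)CC3C5)cc2)CC1` in an ADME assay on microsomes from liver (Rattus norvegicus) for metabolic stability, read by LC-MS, tested at 1 uM (on this read-out higher numbers stand for fast clearance and lower numbers for slow clearance), gives 25 mL.min-1.g-1.
Compound 2 `c1cc([C@H]2CC[C@]3(CC2)OOC2(O3)C3CC4CC(C3)CC2C4)ccc1OCCC1CCNCC1` gives 9 mL.min-1.g-1.
Compound 3 `c1cc([C@H]2CC[C@]3(CC2)OOC2(O3)C3CC4CC(C3)CC2C4)ccc1OC1CCNCC1` gives 21 mL.min-1.g-1.

Among these three numbers compound 3 stands second highest. Its nearest neighbour is compound 1, with a 1.2-fold lower number from compound 1 to compound 3 (0.08 log units; within the scatter), a gap that does not separate the two compounds; its furthest is compound 2, with a 2.3-fold higher number from compound 2 to compound 3 (0.37 log units; beyond the scatter), a gap that does. Compound 4 `CC1(C)CC(O)(COc2ccc([C@H]3CC[C@]4(CC3)OOC3(O4)C4CC5CC(C4)CC3C5)cc2)CC(C)(C)N1` has not yet been measured. It differs from compound 3 in one place: (4-hydroxy-2,2,6,6-tetramethylpiperidin-4-yl)methyl in place of piperidin-4-yl on an oxygen on an aromatic ring.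

Going by the values given here, only one measured step alters the group on the oxygen on the aromatic ring, namely a 2.3-fold higher number from compound 2 to compound 3 (0.37 log units; beyond the scatter), where a shorter group on that oxygen went with a modestly higher number. The two steps from compound 1, a 2.8-fold lower number from compound 1 to compound 2 (0.44 log units; beyond the scatter) and a 1.2-fold lower number from compound 1 to compound 3 (0.08 log units; within the scatter), replace a different group and speak less directly to this change. Among the compounds with values here, none of the measured groups carries the hydroxy or the four methyl groups that the entering group brings, so the data give no firm direction. On this basis compound 4 is expected to show a 1.4-fold lower number from compound 3 to compound 4 (0.15 log units; within the scatter), a shift that may well stay within the scatter. Compound 4 is therefore estimated at 15 mL.min-1.g-1, with a plausible range from 6 mL.min-1.g-1 to 40 mL.min-1.g-1.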

Compound 4, intrinsic clearance in microsomes: < 7 mL.min-1.g-1
Compound 4: only a limit was reported; the forecaster's own chance of this, stated with the estimate: 5%; middle value at least 2.1-fold (0.33 log units) away from the limit.
By their numbers in this assay, from the lowest: compound 2; then compounds 3 and 1 (each within the scatter of the next). At a limit, below all of these: compound 4.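

In this assay compound 4 is reported only as a limit, not as a number: the limit of < 7 mL.min-1.g-1 in this assay, at which 1 of the 4 values shown sits. Going by these compounds alone, earlier, the only measured change on the oxygen on the aromatic ring was a 2.3-fold higher number from compound 2 to compound 3 (0.37 log units; beyond the scatter), which left open what a larger, substituted piperidine group would do here; (4-hydroxy-2,2,6,6-tetramethylpiperidin-4-yl)methyl in place of piperidin-4-yl now gives an at least 3.0-fold lower number from compound 3 to compound 4 (0.47 log units; beyond the scatter), a step that clears the scatter even at its floor and is wider than the step the earlier pair showed at this place. Set against the other compound with a low number, the result reads as an at least 1.2-fold lower number from compound 2 to compound 4 (0.10 log units; that floor lies within the scatter), and since that floor lies within the scatter, the limit alone does not separate the two compounds.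

The compounds shown leave open whether the lower number goes with the hydroxy, with the four methyl groups or with the added methyl linker, a question that a (2,2,6,6-tetramethylpiperidin-4-yl)methyl or a (4-hydroxypiperidin-4-yl)methyl group on the same oxygen would help to settle. They also leave open how an open-chain amine such as a 2-(dimethylamino)ethyl group would read at this place.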